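Removing a Methyl Next to the Ring Nitrogen

The source may report more compounds than this note shows. Statements on the series, on what has been measured and on what is new or still open speak of the compounds shown alone.

Of the compounds shown here, three sharing one core have been measured in a functional assay on U-251 cells (Homo sapiens); on this read-out higher numbers stand for weaker inhibition of growth and lower numbers for stronger inhibition of growth. Compound 1 `Cc1ccnc2nc(-c3ccc(F)cc3)cc(O)c12` gives 36300 nM, and compound 2 `Cc1cc(C)c2c(O)cc(-c3ccc(Cl)cc3)nc2n1` gives 30200 nM. Compound 3 `COc1cccc(-c2cc(O)c3c(C)cc(C)nc3n2)c1`, which carries a methoxyphenyl group, gives 170 nM, the lowest of the three numbers; the nearest, compound 2, lies beyond the scatter, and compound 1 lies further still. Compounds 1 and 2 differ from compound 3 in more than one place, so the three values do not isolate any single change.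

Compound 4 `COc1cccc(-c2cc(O)c3c(C)ccnc3n2)c1` has not yet been measured. It differs from compound 3 by hydrogen in place of methyl on an aromatic carbon, the change sitting on an aromatic carbon of the fused core, next to the ring nitrogen. For the measured compounds named here, no measured pair shows this change alone. Compound 1 lacks that methyl while compound 2 carries it, but their other difference leaves the comparison open.

Compound 4 is therefore expected to give 350 nM, within 100 nM to 1500 nM in this assay. That estimate means a step of a 2.1-fold higher number from compound 3 to compound 4 (0.31 log units; beyond the scatter), a modest weakening that is expected to stay close to the scatter.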

Compound 4, concentration for 50% growth inhibition: 58.9 nM
Estimate against measurement, compound 4: 5.9-fold (0.77 log units) above; the measured number lies below the stated range.
By their numbers in this assay, from the lowest: compound 4; then compound 3; then compounds 2 and 1 (each within the scatter of the next).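

In this assay, putting hydrogen in place of the methyl on this aromatic carbon, next to the ring nitrogen, gives a 2.9-fold lower number from compound 3 to compound 4 (0.46 log units; beyond the scatter). For the compounds shown here, this is the first pair in which the change stands alone, and it shows that inhibition of growth becomes modestly stronger without this methyl, so the methyl is not required at this position for the activity of compound 3. The data at hand offer no explanation for this gain.

Open, as far as these compounds go, is whether another group on this carbon, such as an ethyl, a methoxy or an amine, would give a lower or a higher number than hydrogen does. Also open, from the compounds shown here alone, is whether removing this methyl has the same effect when the methoxyphenyl group is replaced by the fluorophenyl group of compound 1 or the chlorophenyl group of compound 2.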